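The source may hold more compounds than are shown below. What is called first, only, known or untested is meant among the compounds shown, and "the series" means these compounds.

In a physicochemical assay for solubility, read by HPLC, with a stated time of 24 h (on this read-out lower numbers stand for lower solubility and higher numbers for higher solubility), three compounds built on one shared core have been measured, and they differ only in the group on a saturated chain carbon bound to a saturated ring carbon. Compound 1 `O=C1O[C@@H](CN2CCCCC2)CN1c1ccc(-n2cc(-c3ccccn3)cn2)c(F)c1` gives 219000 nM, compound 2 `O=C1O[C@@H](Cn2ccnc2)CN1c1ccc(-n2cc(-c3ccccn3)cn2)c(F)c1` gives 12300 nM, and compound 3 `O=C1O[C@@H](Cn2ccnn2)CN1c1ccc(-n2cc(-c3ccccn3)cn2)c(F)c1` gives 247000 nM. Compound 3 therefore stands at the top of the range together with compound 1, since a 1.1-fold higher number from compound 1 to compound 3 (0.05 log units; within the scatter) stays within the scatter. It stands well clear of compound 2, with a 20-fold higher number from compound 2 to compound 3 (1.30 log units; beyond the scatter) marking a large gap.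

The next structure is compound 4 `CS(=O)(=O)NC[C@H]1CN(c2ccc(-n3cc(-c4ccccn4)cn3)c(F)c2)C(=O)O1`, with methanesulfonamido in place of 1H-1,2,3-triazol-1-yl on a saturated chain carbon bound to a saturated ring carbon. Among the compounds with values here, no measured step makes this exact exchange, so only the steps at the same place bear on it. Of these, a 1.1-fold higher number from compound 1 to compound 3 (0.05 log units; within the scatter) is not beyond the scatter, while an 18-fold lower number from compound 1 to compound 2 (1.25 log units; beyond the scatter) is large. The outcome at this place has thus ranged from no visible change to a large drop, and the data do not show which of these the new group will follow.

A moderate fall is expected, and the range is kept wide. The expected step is a 3.1-fold lower number from compound 3 to compound 4 (0.49 log units; beyond the scatter). For compound 4 the estimated value is 80000 nM, with an expected range from 15000 nM to 300000 nM.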

Compound 4, solubility: 2300 nM
Compound 4: the middle estimate sits 35-fold (1.54 log units) above what was measured, outside the stated range (below it).
By their numbers in this assay, from the lowest: compound 4; then compound 2; then compounds 1 and 3 (each within the scatter of the next).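

In this assay, methanesulfonamido gives the lowest number of the four groups on a saturated chain carbon bound to a saturated ring carbon, with a 110-fold lower number from compound 3 to compound 4 (2.03 log units; beyond the scatter) and a 95-fold lower number from compound 1 to compound 4 (1.98 log units; beyond the scatter) showing a fall larger than any step seen among the ring-bearing groups. Even the previous low end, 1H-imidazol-1-yl, stays clear of it, with a 5.3-fold lower number from compound 2 to compound 4 (0.73 log units; beyond the scatter) as a modest but real gap, so the range at this position reaches further down than the earlier compounds showed. The groups in compound 3 and compound 4 both have 5 heavy atoms and no net charge, yet their numbers lie far apart, so heavy-atom count and net charge alone do not set the read-out here.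

Still open, as far as these compounds go, is whether the fall follows the sulfonyl part or the amide hydrogen, a question that an acetamido group, or a methanesulfonamido group with a methyl on its nitrogen, could address at the same place. The data shown also hold no independent measurement that would account for the fall.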